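Series notes: phenoxy to carbamoyl on the shared core

This account rests on a few compounds, and the source may have more. Where it says the series, first, only, none or still open, it means among the compounds named here.

Three compounds of the series have numbers in an assay on isolated protein for inhibition of 2-Hydroxyacid oxidase 2 (Rattus norvegicus); a higher number here means a weaker inhibitor, a lower number a stronger inhibitor. Compound 1, `Cc1n[nH]c(C(=O)O)c1Cc1cccc(-c2ccc(OC(F)(F)F)cc2)c1`, gives 300 nM in this assay. Compound 2, `Cc1n[nH]c(C(N)=O)c1Cc1cccc(-c2ccc(F)cc2)c1`, gives 1400 nM in this assay. Compound 3, `Cc1n[nH]c(C(=O)O)c1Cc1ccc(Oc2ccccc2)cc1`, gives 500 nM in this assay. Among these three numbers compound 3 stands second highest; its number and that of compound 1 lie within the scatter of each other, so no order between them is claimed, while the number of compound 2 lies beyond the scatter above that of compound 3.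

The next compound, compound 4, is `Cc1n[nH]c(C(=O)O)c1Cc1ccc(C(N)=O)cc1`. Relative to compound 3 the change is carbamoyl in place of phenoxy on an aromatic carbon, in words carbamoyl in place of phenoxy on an aromatic carbon. Within the data shown here, no pair of measured compounds differs by this swap, so no measured step tells how the number should move. The expectation is a step upward in this assay, moderate in size and beyond the scatter, the estimated step from compound 3 to compound 4 being a 3.0-fold higher number from compound 3 to compound 4 (0.48 log units; beyond the scatter). For compound 4 the estimate in this assay is 1500 nM, with a range from 500 nM to 5000 nM.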

Compound 4, half-maximal inhibitory concentration: 1100 nM
Beside the measured number, compound 4's estimate is 1.4-fold (0.13 log units) above it; measured number inside the range.
By their numbers in this assay, from the lowest: compounds 1 and 3 (each within the scatter of the next); then compounds 4 and 2 (each within the scatter of the next).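

Among these compounds, this is the first measured step at this position on the shared core: carbamoyl in place of phenoxy on an aromatic carbon, para to a large group, gives a 2.2-fold higher number from compound 3 to compound 4 (0.34 log units; beyond the scatter) in this assay, modest in size but beyond the scatter. The swap removes the whole six-membered aromatic ring of the phenoxy and adds a hydrogen-bond donor, yet compound 4 still gives 1100 nM, so inhibition in this series does not depend on that ring being present at this position. Nothing available here bears on why the number moves.

This single pair cannot separate the loss of the phenoxy ring from the arrival of the carbamoyl as the source of the step. Going by these compounds, it remains open how a smaller group without a ring, such as a methoxy group, a nitrile or an amine, or a carboxylic acid in place of the carbamoyl, would stand at this position against compound 3 and compound 4.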